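The compounds below may be only part of what the source reports. "The series", "measured", "known", "first", "only" and "open" are said of these compounds alone.

Measured compounds:
- Compound 1, `COc1ccc(NCn2nc(-c3ccc4c(c3)OCCO4)oc2=S)cc1`, gives 5830 nM in a functional assay, with a stated time of 6 min; on this read-out lower numbers stand for stronger inhibition and higher numbers for weaker inhibition.
- Compound 2, `Fc1cccc(NCn2nc(-c3ccc4c(c3)OCCO4)oc2=S)c1`, gives 6620 nM in this assay.

Only these two compounds have been measured, and they share the same core; they differ only in the aromatic group attached to the amine nitrogen. Compound 2 has the higher number of the two, but the step of a 1.1-fold higher number from compound 1 to compound 2 (0.06 log units; within the scatter) is so small that the two values cannot be told apart.

Compound 3, `S=c1oc(-c2ccc3c(c2)OCCO3)nn1CNc1ccccc1Br`, has not yet been measured. It differs from compound 2 in one place: 2-bromophenyl in place of 3-fluorophenyl on an amine nitrogen. Going by the values given here, the only measured step that speaks to this kind of change is the one from compound 1 to compound 2, which also swapped the aromatic group on that same amine nitrogen and produced no movement beyond the scatter. On that basis, no step beyond the scatter is expected in this assay for compound 3 either: the expected step is a 1.0-fold lower number from compound 2 to compound 3 (0.01 log units; within the scatter). Compound 3 is therefore estimated at 6500 nM, with a range from 2500 nM to 17000 nM.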

Compound 3, half-maximal inhibitory concentration: 12700 nM
For compound 3 the middle estimate is 2.0-fold (0.29 log units) below the measured one; the range from low to high includes it.
By their numbers in this assay, from the lowest: compounds 1, 2 and 3 (each within the scatter of the next, the first and the last beyond it).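

In this assay, putting 2-bromophenyl in place of 3-fluorophenyl on the amine nitrogen gives a 1.9-fold higher number from compound 2 to compound 3 (0.28 log units; within the scatter), so this change alone cannot be separated from ordinary variation between repeat measurements. Going by these compounds alone, putting 2-bromophenyl in place of 4-methoxyphenyl gives a 2.2-fold higher number from compound 1 to compound 3 (0.34 log units; beyond the scatter), the first step at this position to pass the scatter, which shows that the choice of aromatic group can shift the read-out modestly towards weaker inhibition. Nothing shown here gives any measured basis for explaining that shift.

As far as these compounds go, two things stay open: whether the change depends on the bromine itself or on its place on the ring, which 2-fluorophenyl and 3-bromophenyl compounds would help to separate, and whether a plain phenyl group would fall in the same narrow range. From the compounds shown here alone, all three compounds also carry an aromatic ring on this nitrogen and share the same core, so the effect of a cyclohexyl group or a longer alkyl chain there remains unknown.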